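Sulfonamide aryl group: from dichlorophenyl to methoxyphenyl

The source may report more compounds than this note shows. Statements on the series, on what has been measured and on what is new or still open speak of the compounds shown alone.

Compound 1, `CC1CCN(C2CCN(S(=O)(=O)c3cccc(-c4ccccc4C(F)(F)F)c3)CC2)CC1`: 10 nM
Compound 2, `CC1CCN(C2CCN(S(=O)(=O)c3ccc(Cl)cc3Cl)CC2)CC1`: 1 nM

In a functional assay on DLD-1 cells (Homo sapiens) for antiproliferative activity, read by CellTiter-Glo, with a stated time of 72 h (a lower number here means a stronger inhibitor, a higher number a weaker inhibitor), compound 2 gives the lowest of the two numbers measured, and compound 1 gives a number that is higher by a gap beyond the usual scatter. Compound 3, `COc1cccc(S(=O)(=O)N2CCC(N3CCC(C)CC3)CC2)c1`, has not yet been measured. It differs from compound 2 in one place: 3-methoxyphenyl in place of 2,4-dichlorophenyl on a sulfonyl sulfur. Among the compounds with values here, no measured pair shows this kind of change, so its effect in this assay can only be guessed. A weakening step is expected, with a 30-fold higher number from compound 2 to compound 3 (1.48 log units; beyond the scatter) going to a higher number beyond the scatter. Compound 3 is therefore expected to give about 30 nM, somewhere between 5 nM and 200 nM.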

Compound 3, half-maximal inhibitory concentration: > 5000 nM
Compound 3 ended at the assay's limit; the forecaster's own chance of this, stated with the estimate: 5%; middle value at least 160-fold (2.22 log units) from the limit.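

Within the data shown here, the earlier compounds showed only that two different aryl groups on the sulfonyl sulfur both allow low numbers; this change shows that the position is not freely interchangeable. Placing 3-methoxyphenyl there in place of 2,4-dichlorophenyl gives an at least 5000-fold higher number from compound 2 to compound 3 (3.69 log units; beyond the scatter), and methoxy in place of 2-(trifluoromethyl)phenyl on an aromatic carbon gives an at least 500-fold higher number from compound 1 to compound 3 (2.69 log units; beyond the scatter). In this assay compound 3 stands at a limit of the assay, not at a number: the limit of > 5000 nM in this assay, at which 1 of the 3 values shown sits.

The compounds shown do not separate the effect of gaining the methoxy from that of losing the two chlorines. From the compounds shown here alone, whether a hydroxyl, an amine or a single chlorine on that phenyl ring would restore a low number remains open.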